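Nitro for Methoxy: Expected Tolerance of Compound 3

A few compounds are considered here, and "the series" means these few. Any claim that something is new, unique, unknown or untested is made for them only; others in the source may bear on it.

Two measured compounds set the frame. Compound 1 `Cc1cc(-c2ccsc2)c2ncc(CSCCc3ccccc3)n2c1` was tested in an ADME assay on HEL cells (Homo sapiens) for cytotoxicity, with a stated time of 3 days (a lower number here means that less compound is tolerated, a higher number that more compound is tolerated), and reaches only a limit of the assay, > 50 ug/mL, not a number. Compound 2 `COc1cccc(-c2cc(C)c3ncc(CSCCc4ccccc4)n3c2)c1` carries a 3-methoxyphenyl group on the shared core; in this assay compound 2 gives 36 ug/mL. Within the data shown here, this is the only plain number in the set. The other value, that of compound 1, is a limit (the limit of > 50 ug/mL in this assay, at which 1 of the 2 values shown sits). Compound 3 `Cc1cc(-c2cccc([N+](=O)[O-])c2)cn2c(CSCCc3ccccc3)cnc12` is the compound still to be measured. It differs from compound 2 by nitro in place of methoxy on an aromatic carbon; cut one bond further out, the change reads 3-methoxyphenyl to 3-nitrophenyl. Among the measured compounds shown here, no measured pair shows this swap, so the step of a 1.1-fold higher number from compound 2 to compound 3 (0.05 log units; within the scatter) is expected to stay within the usual scatter, with no clear direction. Compound 3 is therefore estimated at 40 ug/mL, between 18 ug/mL and 90 ug/mL.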

Compound 3, half-maximal cytotoxic concentration: 43 ug/mL
For compound 3 the middle estimate is 1.1-fold (0.03 log units) below the measured one, within the range that was stated.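

Among these compounds, compound 3 gives the swap at this place a measured size for the first time: in this assay, nitro in place of methoxy gives a 1.2-fold higher number from compound 2 to compound 3 (0.08 log units; within the scatter). On an aromatic carbon of a six-membered aromatic ring of carbon only, meta to a large group, the two groups therefore cannot be told apart in this read-out, and compound 2 and compound 3 now give two plain numbers where there was one. The value of compound 1 remains a limit and not a number: the limit of > 50 ug/mL in this assay, at which 1 of the 3 values shown sits.

On these data alone, whether an amine or a carboxylic acid at the same place would also stay within the scatter remains open. So does whether the step between nitro and methoxy would hold with a longer chain in place of the side chain on the shared core.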